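The source may hold more compounds than are shown below. What is called first, only, known or untested is meant among the compounds shown, and "the series" means these compounds.

Measured so far:
Compound 1 `COCOc1cc(/C=C/C(=O)OCC(=O)Nc2ccc(OC)cc2)ccc1OCc1ccccc1`: in a functional assay on HeLa cells (Homo sapiens) for cytotoxicity, read by MTT assay, with a stated time of 72 h (a lower number here means a stronger inhibitor, a higher number a weaker inhibitor), compound 1 gives 155000 nM.
Compound 2 `COCOc1cc(/C=C/C(=O)OCC(=O)NN2CCOCC2)ccc1OCc1ccccc1`: in this assay compound 2 reaches only a limit of the assay, > 200000 nM.
Compound 3 `O=C(COC(=O)/C=C/c1ccc(O)c(O)c1)NN1CCOCC1`: in this assay compound 3 likewise reaches only a limit, > 200000 nM.

Going by these compounds, compound 2 thus stands at the limit of > 200000 nM in this assay, at which 2 of the 3 values shown sit, a boundary rather than a number, so where its true value lies beyond that boundary is unknown. Among the compounds with values here, the one measured step that touches compound 2 is an at least 1.2-fold higher number from compound 1 to compound 2 (0.11 log units; that floor lies within the scatter), and since its floor lies within the scatter it says little about direction or size. Compound 4 `COCOc1cc(/C=C/C(=O)OCC(=O)NCc2ccco2)ccc1OCc1ccccc1` differs from compound 2 by (furan-2-yl)methyl in place of morpholin-4-yl on an amide-type nitrogen. Within the data shown here, no measured step exchanges two such groups, so the only guide is the neighbouring case of compound 1, which carries 4-methoxyphenyl on the same nitrogen and gives 155000 nM. Compound 2 itself sits at its limit. Both of these are weak, and a step of an at least 1.1-fold lower number from compound 2 to compound 4 (0.04 log units; that floor lies within the scatter) is therefore expected, meaning no clear movement beyond the scatter. For compound 4 the estimate in this assay is 180000 nM, with a range from 80000 nM to 400000 nM, and there is a fair chance that the assay again reports only a limit.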

Compound 4, half-maximal inhibitory concentration: > 200000 nM
Compound 4: a limit, no number; the forecaster's own chance of this, stated with the estimate: 50%; middle value at least 1.1-fold (0.04 log units) from the limit.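

Compound 4 gives only a limit in this assay, > 200000 nM, so a five-membered aromatic ring on a one-carbon link, (furan-2-yl)methyl, ends at the same boundary as the six-membered non-aromatic morpholin-4-yl. Within the data shown here, the step between compound 2 and compound 4 cannot be read, since both ends are limits, while the one readable comparison is an at least 1.2-fold higher number from compound 1 to compound 4 (0.11 log units; that floor lies within the scatter), so its direction and size stay uncertain. This position on the amide-type nitrogen has now taken three different groups without any clear gain in cytotoxicity, and the series is crowded against the ceiling of the read-out: the limit of > 200000 nM in this assay, at which 3 of the 4 values shown sit.

Going by these compounds, it remains open whether any group on this nitrogen can bring the number well down, for example a long alkyl chain, or a chain ending in an amine or a carboxylic acid. On these data alone, with so many values at a limit, the real differences among compound 2, compound 3 and compound 4 also remain unknown.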